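The source may report more compounds than this note shows. Statements on the series, on what has been measured and on what is new or still open speak of the compounds shown alone.

Measured in an ADME assay for permeability, using PAMPA, at pH 4; a higher number here means that the compound crosses the layer faster, a lower number that the compound crosses the layer more slowly:
Compound 1 `CCCCC#Cc1c(C)[nH]c2ccccc2c1=O`: 500 10^-6 cm/s
Compound 2 `CCCCC#Cc1c(C)[nH]c2ccc(Cl)cc2c1=O`: 171 10^-6 cm/s
Compound 3 `COc1cc2[nH]c(C)c(C3CCCCC3)c(=O)c2cc1Cl`: 1240 10^-6 cm/s

Compound 3 has the highest number of the three, and its gaps to compound 1 and compound 2 both lie beyond the scatter. Compound 4 `CCCCC/C=C/c1c(C)[nH]c2cc(OC)c(Cl)cc2c1=O` differs from compound 3 in one place: hept-1-en-1-yl in place of cyclohexyl on an aromatic carbon. In words, hept-1-en-1-yl stands in place of cyclohexyl on an aromatic carbon. Going by the values given here, no measured step covers this swap. Among the compounds with values here, the only measured step, a 2.9-fold lower number from compound 1 to compound 2 (0.47 log units; beyond the scatter), is chloro in place of hydrogen, and compound 3 and compound 4 both carry that chloro, so it bears only on the likely size of a change. Compound 1 at 500 10^-6 cm/s and compound 2 at 171 10^-6 cm/s have an open chain rather than a ring in that place, and both lie lower than compound 3, though they also differ from it elsewhere. A modest fall in this assay is therefore expected, with wide uncertainty. The expected change is a 3.1-fold lower number from compound 3 to compound 4 (0.49 log units; beyond the scatter). For compound 4 the estimate is 400 10^-6 cm/s, with an expected range from 130 10^-6 cm/s to 1200 10^-6 cm/s.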

Compound 4, apparent permeability: 280 10^-6 cm/s
The estimate for compound 4 lay 1.4-fold (0.15 log units) above the measured number; low and high end bracket the measured number.
By their numbers in this assay, from the lowest: compounds 2, 4 and 1 (each within the scatter of the next, the first and the last beyond it); then compound 3.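

Putting hept-1-en-1-yl in place of cyclohexyl on an aromatic carbon gives, in this assay, a 4.4-fold lower number from compound 3 to compound 4 (0.65 log units; beyond the scatter), the only step shown at this position; the one earlier step concerned chloro in place of hydrogen. The position, ortho to a methyl group and two atoms from the ring nitrogen, is therefore not indifferent to its group, as a carbon-only ring and an open chain with a double bond read differently here on the same core. Nothing available explains this step.

The compounds shown leave open whether losing the ring or gaining the double bond matters more, which a saturated heptyl chain at this position could separate. Also open, going by these compounds, is how an amine or a carboxylic acid on that chain would read in this assay.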